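Stereoisomer of a beta-amino acid integrin alpha-4/beta-1 inhibitor

The source may report more compounds than this note shows. Statements on the series, on what has been measured and on what is new or still open speak of the compounds shown alone.

Compound 1 `CC(C)[C@@H](CC(=O)O)NC(=O)[C@@H]1CCCN1S(=O)(=O)c1cc(Cl)cc(Cl)c1`: 8.9 nM
Compound 2 `C/C=C/[C@@H](CC(=O)O)NC(=O)[C@@H]1CCCN1S(=O)(=O)c1cc(Cl)cc(Cl)c1`: 13 nM

In an assay on RPMI-8866 cells for inhibition of integrin alpha-4/beta-1 (Homo sapiens) (on this read-out higher numbers stand for weaker inhibition and lower numbers for stronger inhibition), compound 2 gives the highest of the two numbers recorded, and its nearest neighbour is compound 1, which sits within the scatter of it. Among the measured compounds shown here, the one measured step, a 1.5-fold higher number from compound 1 to compound 2 (0.16 log units; within the scatter), shows that isopropyl and prop-1-en-1-yl on that chain carbon are interchangeable on this read-out.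

Compound 3 `CC(C)[C@H](CC(=O)O)NC(=O)[C@@H]1CCCN1S(=O)(=O)c1cc(Cl)cc(Cl)c1` differs from compound 2 by 1-(carboxymethyl)-2-methylpropyl in place of 1-(carboxymethyl)but-2-en-1-yl on an amide-type nitrogen. For the measured compounds named here, the groups involved match compound 1, but the stereocentre in compound 3 is defined in the opposite sense to compound 1, and no measured step covers such an inversion. The step from compound 1 to compound 2 therefore bears only on the alkyl exchange, for which no change beyond the scatter is expected; the inverted stereocentre is uncharted, so compound 3 is estimated weaker, with wide uncertainty: 60 nM (9 nM to 500 nM), a step of a 4.6-fold higher number from compound 2 to compound 3 (0.66 log units; beyond the scatter).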

Compound 3, half-maximal inhibitory concentration: 362 nM
Compound 3: the middle estimate sits 6.0-fold (0.78 log units) below what was measured; low and high end bracket the measured number.
By their numbers in this assay, from the lowest: compounds 1 and 2 (each within the scatter of the next); then compound 3.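

In this assay, the configuration of the saturated chain carbon turns out to matter far more than the group it carries: inverting it gives a 41-fold higher number from compound 1 to compound 3 (1.61 log units; beyond the scatter), whereas exchanging isopropyl for prop-1-en-1-yl had stayed within the scatter. Going from 1-(carboxymethyl)but-2-en-1-yl to the inverted 1-(carboxymethyl)-2-methylpropyl on the amide-type nitrogen likewise gives a 28-fold higher number from compound 2 to compound 3 (1.44 log units; beyond the scatter), so the new compound stands well apart from both earlier ones. The large gap can be laid to that one inversion alone: the fact that compounds 1 and 3 differ only in the configuration as drawn

The compounds shown leave open whether the same inversion would cost as much with prop-1-en-1-yl on that carbon. They also leave open how either configuration would fare with a phenyl ring or a longer chain there.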